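Aryl versus alkynyl substituents on a shared nucleoside core

The source may report more compounds than this note shows. Statements on the series, on what has been measured and on what is new or still open speak of the compounds shown alone.

Measured compounds:
compound 1 `CCCC#Cc1cc([C@@H]2O[C@H](CO)[C@@H](O)[C@H]2O)n2ncnc(N)c12` with 20 nM
compound 2 `Nc1ncnn2c([C@@H]3O[C@H](CO)[C@@H](O)[C@H]3O)cc(C#CC3CC3)c12` with 20 nM
compound 3 `Nc1ncnn2c([C@@H]3O[C@H](CO)[C@@H](O)[C@H]3O)cc(-c3ccccc3)c12` with 65200 nM

In a functional assay on CAPAN-1 cells (Homo sapiens) for antiproliferative activity, with a stated time of 72 h (a lower number here means a stronger inhibitor, a higher number a weaker inhibitor), compound 1 and compound 2 give numbers within the scatter of each other, no change at the digits printed from compound 1 to compound 2 (within the scatter). Compound 3 has the highest number of the three: the step of a 3300-fold higher number from compound 1 to compound 3 (3.51 log units; beyond the scatter) and the step of a 3300-fold higher number from compound 2 to compound 3 (3.51 log units; beyond the scatter) are both large and beyond the scatter, so compound 3 is the weakest inhibitor among the measured compounds in this assay.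

Compound 4 `Nc1ncnn2c([C@@H]3O[C@H](CO)[C@@H](O)[C@H]3O)cc(-c3ccc(Cl)cc3)c12` differs from compound 3 in one place: chloro in place of hydrogen on an aromatic carbon. Among the compounds with values here, no measured step touches a substituent on that ring; the two measured steps concern only the exchange of an alkynyl group for phenyl, and both are large in the same direction. They say nothing about what a chloro group on the phenyl does in this assay. The expectation for compound 4 is therefore a step of a 1.3-fold lower number from compound 3 to compound 4 (0.12 log units; within the scatter) that stays within the scatter. Compound 4 is expected to give 50000 nM, with a range from 15000 nM to 150000 nM.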

Compound 4, half-maximal inhibitory concentration: 56700 nM
Compound 4: the middle estimate sits 1.1-fold (0.05 log units) below what was measured; the range from low to high includes it.
By their numbers in this assay, from the lowest: compounds 1 and 2 (each within the scatter of the next); then compounds 4 and 3 (each within the scatter of the next).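

In this assay a chloro group on the phenyl ring, para to a large group, leaves the number in place (a 1.1-fold lower number from compound 3 to compound 4 (0.06 log units; within the scatter)), so this change on the ring gives no recovery of the activity seen with the alkynyl groups. The distance from the alkynyl compounds remains large with 4-chlorophenyl at this position (both a 2800-fold higher number from compound 2 to compound 4 (3.45 log units; beyond the scatter) and a 2800-fold higher number from compound 1 to compound 4 (3.45 log units; beyond the scatter)), so compounds 3 and 4 now give two aryl examples on the same side of that gap. No measurement at hand bears on why the phenyl and 4-chlorophenyl compounds sit so far from the alkynyl compounds.

Going by these compounds, whether an amine, a carboxylic acid or a methoxy group on the phenyl ring would move the number remains open. Also open, on these data alone, is how far the alkynyl group tolerates change beyond propyl and cyclopropyl, for example a longer chain or a hydroxymethyl end.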